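Carbamate in Place of Methyl on a Bis-Aziridinyl Quinone

A few compounds are considered here, and "the series" means these few. Any claim that something is new, unique, unknown or untested is made for them only; others in the source may bear on it.

Compound 2, `CCCC1=C(N2CC2)C(=O)C(CCC)=C(N2CC2)C1=O`, stands lowest of the three measured compounds in a functional assay on L1210 cells (Mus musculus), with a stated time of 1 days (on this read-out lower numbers stand for lower potency and higher numbers for higher potency (the scale is a negative logarithm)), giving 4.14. Compound 1, `CC1=C(N2CC2)C(=O)C(CC(C)OC(N)=O)=C(N2CC2)C1=O`, carries a carbamate-bearing side chain and gives 5.18; compound 3, `CC1=C(N2CC2)C(=O)C(N2CC2)=C(N2CC2)C1=O`, gives 5.69. Within the data shown here, the one step measured in one place, a number 0.51 log units higher from compound 1 to compound 3 (beyond the scatter), exchanges the carbamate chain for a ring and so does not isolate the change now considered. Compound 4, `CCCC1=C(N2CC2)C(=O)C(CCOC(N)=O)=C(N2CC2)C1=O`, differs from compound 2 by carbamoyloxy in place of methyl on a saturated chain carbon, two bonds along the chain from a double-bonded ring carbon. Among the measured compounds shown here, no measured step bears directly on this exchange; only the two values of compound 1 and compound 2 hint that a carbamate-bearing chain goes with a higher number. An increase is therefore expected, a number 0.66 log units higher from compound 2 to compound 4 (beyond the scatter), and compound 4 is estimated at 4.8, within 4.3 to 5.4.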

Compound 4, logarithm of the reciprocal of the active concentration, log(1/C): 4.42
Compound 4: middle estimate off by 0.38 log units, on the high side; low and high end bracket the measured number.
By their numbers in this assay, from the lowest: compounds 2 and 4 (each within the scatter of the next); then compound 1; then compound 3.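

In this assay, among these compounds, the step of carbamoyloxy in place of methyl on a saturated chain carbon reads as a number 0.28 log units higher from compound 2 to compound 4 (within the scatter) and so gives the first direct reading of this exchange, one that does not separate the two compounds. Compound 1 and compound 2 differ in more than one place and could not show this. No measurement at hand accounts for the result. On these data alone, whether an amine or a carboxylic acid at this place would separate from compound 2 stays open, as does the reading of a longer chain bearing the carbamate.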